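Aroylurea thiazole hydrazones: one acyl swap on a common core

The source may hold more compounds than are shown below. What is called first, only, known or untested is meant among the compounds shown, and "the series" means these compounds.

Measured so far:
compound 1, `CN(C(=O)NC(=O)c1ccc(Cl)cc1Cl)c1nc(C(F)(F)F)c(C(=O)N/N=C/c2cccc(C(F)(F)F)c2)s1`, 11.2 ug/mL
compound 2, `CN(C(=O)NC(=O)c1ccc(F)c(F)c1)c1nc(C(F)(F)F)c(C(=O)N/N=C/c2ccccc2C(F)(F)F)s1`, 10.4 ug/mL
compound 3, `CN(C(=O)NC(=O)c1ccc(C(F)(F)F)cc1)c1nc(C(F)(F)F)c(C(=O)N/N=C/c2cccc(C(F)(F)F)c2)s1`, 7.95 ug/mL

In a functional assay on HepG2 cells (Homo sapiens) for inhibition, read by MTT assay, with a stated time of 72 h (a lower number here means a stronger inhibitor, a higher number a weaker inhibitor), compound 3 gives the lowest of the three numbers, yet compound 2 and compound 1 both lie within the scatter of it, so no order among them can be claimed. Among the measured compounds shown here, the one step between compounds that differ in a single place, a 1.4-fold lower number from compound 1 to compound 3 (0.15 log units; within the scatter), was itself within the scatter. Compound 4, `CN(C(=O)NC(=O)c1ccc(F)c(F)c1)c1nc(C(F)(F)F)c(C(=O)N/N=C/c2cccc(C(F)(F)F)c2)s1`, carries the change (3,4-difluorophenyl in place of 4-(trifluoromethyl)phenyl on a carbonyl carbon). For the measured compounds named here, the only step that bears on it, that from compound 1 to compound 3, was small, and compound 2, which carries the same 3,4-difluorophenyl group, sits within the scatter of compound 3. Compound 4 is therefore expected to show a 1.2-fold higher number from compound 3 to compound 4 (0.08 log units; within the scatter), with an estimated value of 9.5 ug/mL, between 4.5 ug/mL and 20 ug/mL.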

Compound 4, half-maximal inhibitory concentration: 5.6 ug/mL
Compound 4: the middle estimate sits 1.7-fold (0.23 log units) above what was measured; the range from low to high includes it.
By their numbers in this assay, from the lowest: compounds 4, 3, 2 and 1 (each within the scatter of the next).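

In this assay, the three aryl groups on the carbonyl carbon now compare on one otherwise unchanged structure, and neither 3,4-difluorophenyl step leaves the scatter (a 1.4-fold lower number from compound 3 to compound 4 (0.15 log units; within the scatter); a 2.0-fold lower number from compound 1 to compound 4 (0.30 log units; within the scatter)). The other end of the molecule now gets its first reading, with 3-(trifluoromethyl)phenyl in place of 2-(trifluoromethyl)phenyl on a carbon with a double bond to nitrogen, and that step also stays within the scatter (a 1.9-fold lower number from compound 2 to compound 4 (0.27 log units; within the scatter)). Nothing available explains these steps. From the compounds shown here alone, whether an amine or a carboxylic acid on the phenyl ring at this carbonyl carbon would move the number beyond the scatter remains open.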